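The source may report more compounds than this note shows. Statements on the series, on what has been measured and on what is new or still open speak of the compounds shown alone.

Measured in a functional assay on SN12C cells (Homo sapiens) for inhibition, read by sulforhodamine B assay, with a stated time of 48 h; a lower number here means that less compound is tolerated, a higher number that more compound is tolerated:
compound 1, `O=C(Nc1cccc(-n2cc(-c3ccncc3)c(-c3ccc(Cl)c(O)c3)n2)c1)Nc1cccc(C(F)(F)F)c1`: > 32500 nM
compound 2, `COc1cc(-c2nn(-c3cccc(NC(=O)Nc4cc(C(F)(F)F)cc(C(F)(F)F)c4)c3)cc2-c2ccncc2)ccc1Cl`: > 50000 nM
compound 3, `COc1cc(-c2nn(-c3cccc(NC(=O)c4cccc(C(F)(F)F)c4)c3)cc2-c2ccncc2)ccc1Cl`: > 50000 nM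

Compound 3 gives no number in this assay, only a limit, > 50000 nM. Compound 2 likewise sits at a limit, > 50000 nM. Compound 1 sits at a limit as well, > 32500 nM, at a lower cut-off than the other two, so nothing can be said about the order of the three. Two of the three values share the same limit (the limit of > 50000 nM in this assay, at which 2 of the 3 values shown sit), and the third sits at a different one (the limit of > 32500 nM in this assay, at which 1 of the 3 values shown sits). Within the data shown here, no step between measured compounds is available here.

Compound 4, `COc1cc(-c2nn(-c3cccc(NC(=O)Nc4ccc(Cl)c(C(F)(F)F)c4)c3)cc2-c2ccncc2)ccc1Cl`, is still to be measured. It differs from compound 3 in one place: (4-chloro-3-(trifluoromethyl)phenyl)amino in place of 3-(trifluoromethyl)phenyl on a carbonyl carbon. Compound 2, which also carries an amino group on its carbonyl carbon, gives only a limit, and compound 3 without that amino group gives only a limit, so the change is not expected to move the value beyond the scatter in either direction. For compound 4 the step from compound 3 to compound 4 is expected to be a step that the limit leaves unreadable from compound 3 to compound 4. Compound 4 is therefore estimated at 60000 nM, within 15000 nM to 250000 nM, and most likely it will again be reported only as a limit.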

Compound 4, concentration lethal to 50% of the cells: > 32500 nM
Compound 4 gave a limit, no number; the forecaster's own chance of this, stated with the estimate: 80%; the middle value does not contradict the limit.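

In this assay compound 4 gives only a limit, > 32500 nM. Compound 3 likewise gives only a limit, > 50000 nM. No step can be read between compound 3 and compound 4. The compounds shown leave open whether (4-chloro-3-(trifluoromethyl)phenyl)amino in place of 3-(trifluoromethyl)phenyl on a carbonyl carbon changes the value in this assay at all.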